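A few compounds are considered here, and "the series" means these few. Any claim that something is new, unique, unknown or untested is made for them only; others in the source may bear on it.

Working notes on the series.

The three measured compounds share one core and differ only at a saturated ring carbon of the five-membered ring. Compound 1 `Cc1ccccc1Cc1ccc(N2CCC[C@H]2CC(=O)O)cc1` carries hydrogen there and in an assay on HEK293 cells for binding affinity to Free fatty acid receptor 1 (Homo sapiens), read by scintillation counting and radioligand binding, with a stated time of 1 h (a lower number here means a stronger inhibitor, a higher number a weaker inhibitor), compound 1 gives 1300 nM. Compound 2 `Cc1ccccc1Cc1ccc(N2C[C@@H](C)C[C@H]2CC(=O)O)cc1` carries methyl and in this assay compound 2 gives 360 nM, so that a 3.6-fold lower number from compound 1 to compound 2 (0.56 log units; beyond the scatter). Compound 3 `Cc1ccccc1Cc1ccc(N2C[C@@H](C(F)(F)F)C[C@H]2CC(=O)O)cc1` carries trifluoromethyl and in this assay compound 3 gives 73 nM, the lowest of the three numbers; a 4.9-fold lower number from compound 2 to compound 3 (0.69 log units; beyond the scatter) and an 18-fold lower number from compound 1 to compound 3 (1.25 log units; beyond the scatter), both beyond the scatter. Among the compounds with values here, each substitution at that carbon so far has lowered the number, with no compound going against it.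

Compound 4 `Cc1ccccc1Cc1ccc(N2C[C@@H](c3ccccc3)C[C@H]2CC(=O)O)cc1` is not yet measured. The change from compound 3 is phenyl in place of trifluoromethyl on a saturated ring carbon. Within the data shown here, no measured step replaces trifluoromethyl by an aromatic ring, so the steps from compound 1 to compound 2, from compound 2 to compound 3 and from compound 1 to compound 3 bear on it only by showing that this ring carbon tolerates substitution and that each replacement so far improved this assay. A modest step from compound 3 to compound 4, or none beyond the scatter, is expected, with direction uncertain, i.e. a 1.0-fold lower number from compound 3 to compound 4 (0.02 log units; within the scatter) is the estimate. For compound 4 the expected value in this assay is 70 nM, within 15 nM to 300 nM.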

Compound 4, inhibition constant: > 25000 nM
Compound 4 was reported as a limit (the forecaster's own chance of this, stated with the estimate: 3%); at least 350-fold (2.55 log units) between middle value and limit.
By their numbers in this assay, from the lowest: compound 3; then compound 2; then compound 1. At a limit, above all of these: compound 4.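

In this assay compound 4 is reported only as a limit of the assay, not as a number: the limit of > 25000 nM in this assay, at which 1 of the 4 values shown sits.

This ring carbon therefore does not accept every group, a point that the methyl and trifluoromethyl compounds could not show: the change to phenyl gives an at least 340-fold higher number from compound 3 to compound 4 (2.53 log units; beyond the scatter) and, measured against methyl, an at least 69-fold higher number from compound 2 to compound 4 (1.84 log units; beyond the scatter). Phenyl also falls behind plain hydrogen, with an at least 19-fold higher number from compound 1 to compound 4 (1.28 log units; beyond the scatter), so the earlier lowering of the number with substitution at this carbon holds for methyl and trifluoromethyl only, and compound 4 goes against it.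

The compounds shown do not separate the presence of an aromatic ring from the larger count of heavy atoms as the feature linked to this loss, since phenyl differs from trifluoromethyl in both. On these data alone, an ethyl group, a cyclohexyl ring or a pyridine ring at the same carbon would bear on that question, and how a hydroxyl group or an amine would behave there also remains open.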